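The compounds below may be only part of what the source reports. "The series", "measured", "known", "first", "only" and "open" are said of these compounds alone.

Measured so far in an ADME assay on microsomes from liver (Homo sapiens) for metabolic stability; on this read-out lower numbers stand for slow clearance and higher numbers for fast clearance:

- Compound 1 `CCCOc1cncc2nnc(-c3cnn(C)c3-c3ccc(C(F)(F)F)cc3)n12`: > 300 mL/min/kg
- Compound 2 `CCc1ccc(-c2c(-c3nn(C)c4ncnc(N5CC(NC(=O)OC)C5)c34)cnn2C)cc1`: 42 mL/min/kg
- Compound 3 `Cc1ccc(-c2c(-c3nn(C)c4ncnc(N5CCC5)c34)cnn2C)cc1`: 47 mL/min/kg

The reported value of compound 1 is a limit of the assay and not a number. Compound 3, at 47 mL/min/kg, stands level with compound 2, at 42 mL/min/kg. The two values lie within the usual scatter of repeated measurements.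

The next compound to be tested is compound 4 `Cn1ncc(-c2nn(C)c3ncnc(N4CCC4)c23)c1-c1ccccc1`. It differs from compound 3 at a single place: hydrogen in place of methyl on an aromatic carbon. This puts hydrogen in place of methyl on an aromatic carbon, turning 4-methylphenyl into phenyl.

For the measured compounds named here, no measured pair here shows this change alone, so there is no direct precedent for its size in this assay. Only a modest effect is therefore expected. The estimated step of a 1.2-fold lower number from compound 3 to compound 4 (0.09 log units; within the scatter) is small and downward, and it is expected to stay within the scatter. Compound 4 is estimated at 38 mL/min/kg, with an expected range of 18 mL/min/kg to 80 mL/min/kg.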

Compound 4, clearance: 34 mL/min/kg
The estimate for compound 4 lay 1.1-fold (0.05 log units) above the measured number; the measured number falls inside the stated range.
By their numbers in this assay, from the lowest: compounds 4, 2 and 3 (each within the scatter of the next). At a limit, above all of these: compound 1.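

In this assay, for the compounds shown here, hydrogen in place of methyl on an aromatic carbon, para to a large group, turns 4-methylphenyl into phenyl and gives a 1.4-fold lower number from compound 3 to compound 4 (0.14 log units; within the scatter) as the first step that can be read at this position. The numbers for compound 3 and compound 4 cannot be told apart, so the methyl is not shown to matter for clearance on this shared core. No measurement shown here bears on the reason for this result.

From the compounds shown here alone, whether a chlorine atom, a methoxy group or a carboxylic acid on this same aromatic carbon would give a step beyond the scatter remains open. Compound 2 carries an ethyl group on this ring but also differs from compound 3 in a second place, so the ethyl group cannot be judged on its own.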